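The source may report more compounds than this note shows. Statements on the series, on what has been measured and on what is new or still open speak of the compounds shown alone.

In a functional assay on HUVEC cells (Homo sapiens) for inhibition, using NADPH, with a stated time of 2 h (a higher number here means a weaker inhibitor, a lower number a stronger inhibitor), compound 1 (`CCCCCCCCCc1[nH]c2ccccc2c(=O)c1C`) gives 5.6 nM and compound 2 (`Cc1c(COCCCCO)[nH]c2ccccc2c1=O`) gives 2600 nM as its value. Compound 3 (`CCCCOc1cccc(OCc2[nH]c3ccccc3c(=O)c2C)c1`) gives 4.7 nM as its value, within the scatter of compound 1 and far beyond the scatter from compound 2. Compound 4 (`COC(C)(C)CCOc1cccc(OCc2[nH]c3ccccc3c(=O)c2C)c1`) awaits measurement. It carries 1-methoxy-1-methylethyl in place of ethyl on a saturated chain carbon, two bonds along the chain from an oxygen on an aromatic ring. Among the measured compounds shown here, with no measured step to guide it, the expectation rests on compound 3 at 4.7 nM and allows for a modest loss. The expected change is an estimated 2.6-fold higher number from compound 3 to compound 4 (0.41 log units; beyond the scatter) toward weaker inhibition. For compound 4 the estimate is 12 nM with an expected range from 3 nM to 50 nM in this measurement.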

Compound 4, half-maximal inhibitory concentration: 8.3 nM
The estimate for compound 4 lay 1.4-fold (0.16 log units) above the measured number, and the stated range covers the measured number.
By their numbers in this assay, from the lowest: compounds 3, 1 and 4 (each within the scatter of the next); then compound 2.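

In this assay, among the compounds shown here, the change from ethyl to 1-methoxy-1-methylethyl gives a 1.8-fold higher number from compound 3 to compound 4 (0.25 log units; within the scatter) and so gives the first reading at this position, where the earlier compounds offered no step. Swapping butoxy for 3-methoxy-3-methylbutoxy adds heavy atoms and a hydrogen-bond acceptor at the chain end, yet the two numbers cannot be told apart. Nothing available explains this result. From the compounds shown here alone, it remains open whether an amine or a carboxylic acid at this chain end would keep the number this low. A longer chain is equally unresolved.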